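A few compounds are considered here, and "the series" means these few. Any claim that something is new, unique, unknown or untested is made for them only; others in the source may bear on it.

Compound 1 `CC(C)N(Cc1cccc(OCCCCCC(=O)O)c1)C(=O)c1ccc(-c2ccco2)cc1` is one of three measured compounds.
Compound 2 `CC(C)N(Cc1cccc(OCCCCCC(=O)O)c1)C(=O)c1ccc(-c2cccc(Oc3ccccc3)c2)cc1` is the second.
Compound 3 `CC(C)N(Cc1cccc(OCCCCCC(=O)O)c1)C(=O)c1ccc(-c2cccc(Br)c2)cc1` is the third.

In an ADME assay on HepG2 cells (Homo sapiens) for cytotoxicity, read by CellTiter-Glo and resazurin assay, with a stated time of 72 h (a lower number here means that less compound is needed, a higher number that more compound is needed for the effect), compound 1 reaches only the assay limit, > 26000 nM. Compound 2 also reaches only a limit in this assay, > 18700 nM. Compound 3 likewise shows only a limit, > 26000 nM. So compound 1 stands at a limit, and the two other values are limits too; the limit of > 26000 nM in this assay, at which 2 of the 3 values shown sit, and the limit of > 18700 nM in this assay, at which 1 of the 3 values shown sits, together describe everything measured here.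

Compound 4 `CC(C)N(Cc1cccc(OCCCCCC(=O)O)c1)C(=O)c1ccc(-c2cccc(Cl)c2)cc1` has not yet been measured. It differs from compound 1 by 3-chlorophenyl in place of furan-2-yl on an aromatic carbon. The measured steps closest to this change are a step that the two limits leave unreadable from compound 1 to compound 3 and a step that the two limits leave unreadable from compound 2 to compound 3; neither can be read as a size, since both ends sit at limits. No step in either direction beyond the scatter can therefore be expected for compound 4 in this assay; the likeliest outcome is another limit.

Compound 4 is estimated at 30000 nM, with a range from 15000 nM to 60000 nM. The step this estimate implies is expected to be a step that the limit leaves unreadable from compound 1 to compound 4.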

Compound 4, half-maximal effective concentration: > 21900 nM
Compound 4 ended at the assay's limit (the forecaster's own chance of this, stated with the estimate: 85%); the middle value does not contradict the limit.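

In this assay, among these compounds, compound 4 gives only a limit, > 21900 nM, and compounds 1, 2 and 3 also give only limits, so no step between them and compound 4 can be read. The compounds shown leave open the concentration at which any of them would reach the half-maximal effect, and whether exchanging these groups changes it.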